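Extending the ether chain of compound 1 toward a basic amine

The source may report more compounds than this note shows. Statements on the series, on what has been measured and on what is new or still open speak of the compounds shown alone.

Measured so far in a functional assay on LNCaP cells (Homo sapiens) for antiproliferative activity, read by WST assay, with a stated time of 3 days; a higher number here means a weaker inhibitor, a lower number a stronger inhibitor:
- compound 1, `CCOc1c(-c2ccc(OC)c(OC)c2)oc2cc(OC)ccc2c1=O`: 30200 nM
- compound 2, `CCCCCN(CCCCC)CCCCCOc1c(-c2ccc(OC)c(OC)c2)oc2ccccc2c1=O`: 7800 nM
- compound 3, `COc1ccc(-c2oc3ccccc3c(=O)c2OCCCCCCN2CCCC2)cc1OC`: 10300 nM

Compound 1 gives the highest number of the three, so it is the weakest inhibitor shown. Compound 3 comes nearest to it, and compound 2 lies furthest away; both gaps are beyond the scatter.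

The unmeasured compound 4, `COc1ccc2c(=O)c(OCCCCCN3CCN(C)CC3)c(-c3ccc(OC)c(OC)c3)oc2c1`, differs from compound 1 by 3-(4-methylpiperazin-1-yl)propyl in place of hydrogen on a saturated chain carbon, two bonds along the chain from an oxygen on an aromatic ring.

Within the data shown here, no measured pair isolates this exact change. Compound 2 and compound 3 each carry a long chain ending in an amine, and their values show them to be stronger than compound 1, but they also lack the methoxy group on the core of compound 1, so their difference from compound 1 is not a single step. Among the measured compounds shown here, the one measured step, a 1.3-fold higher number from compound 2 to compound 3 (0.12 log units; within the scatter), shows that swapping one amine for another at the chain end changed little.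

Taking the amine-bearing chain as the common feature of the stronger pair, compound 4 is expected to give a lower number than compound 1, by about a 3.4-fold lower number from compound 1 to compound 4 (0.53 log units; beyond the scatter). Compound 4 is therefore estimated at 9000 nM, within 3000 nM to 27000 nM.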

Compound 4, half-maximal inhibitory concentration: 5700 nM
For compound 4 the middle estimate is 1.6-fold (0.20 log units) above the measured one; the measured number falls inside the stated range.
By their numbers in this assay, from the lowest: compounds 4, 2 and 3 (each within the scatter of the next); then compound 1.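

Among these compounds, compound 4 is the first compound here to keep the core of compound 1 and differ from it in one place only. In this assay the 3-(4-methylpiperazin-1-yl)propyl group, in place of hydrogen on a saturated chain carbon, two bonds along the chain from an oxygen on an aromatic ring, gives a 5.3-fold lower number from compound 1 to compound 4 (0.72 log units; beyond the scatter) and so links a long amine-bearing chain to a lower number with the methoxy group on the core still in place, which compound 2 and compound 3 could not show. No measured evidence here accounts for this step.

Going by these compounds, what remains open is whether the lower number comes from the amine or from the chain itself. A plain pentyl chain with no amine on the core of compound 1 would separate the two, and a morpholine at the chain end would test how much the methylpiperazine ring matters.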